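This account rests on a few compounds, and the source may have more. Where it says the series, first, only, none or still open, it means among the compounds named here.

Measured in an assay on cell membranes for displacement of a labelled ligand from Cholecystokinin receptor type A (Rattus norvegicus), read by CCK-8 assay, with a stated time of 2 h; a higher number here means a weaker inhibitor, a lower number a stronger inhibitor:
compound 1 `O=C1C=C(Cl)C(O)(c2ccccc2)N1C1CC1` gives 7500 nM
compound 2 `O=C1C=C(Cl)C(O)(c2ccc(Cl)cc2)N1C1CC1` gives 4000 nM
compound 3 `CC(C)(C)N1C(=O)C=C(Cl)C1(O)c1ccccc1` gives 120 nM

Compound 2 stands second highest of the three numbers in this assay. Its nearest neighbour is compound 1, separated by a 1.9-fold lower number from compound 1 to compound 2 (0.27 log units; within the scatter), a chloro in place of hydrogen on an aromatic carbon that changes nothing beyond the scatter. Its furthest neighbour is compound 3, whose lower number lies beyond the scatter of compound 2.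

Compound 4 `CCCCCCN1C(=O)C=C(Cl)C1(O)c1ccc(Cl)cc1` is not yet measured. It differs from compound 2 in one place: hexyl in place of cyclopropyl on an amide-type nitrogen in a ring. Within the data shown here, the only measured step that touches this nitrogen is a 63-fold lower number from compound 1 to compound 3 (1.80 log units; beyond the scatter), where cyclopropyl also left, but the entering group there was tert-butyl, not hexyl; no measured pair shows what an open chain on this nitrogen does, and the chloro difference between compound 1 and compound 2 is within the scatter. The step to compound 4 is therefore expected to lower the number in this assay, most likely beyond the scatter but by less than the tert-butyl step, with wide uncertainty. The expected step is a 5.0-fold lower number from compound 2 to compound 4 (0.70 log units; beyond the scatter). Compound 4 is estimated at 800 nM, within a range of 150 nM to 4000 nM.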

Compound 4, half-maximal inhibitory concentration: 3600 nM
Compound 4: middle estimate off by 4.5-fold (0.65 log units), on the low side; low and high end bracket the measured number.
By their numbers in this assay, from the lowest: compound 3; then compounds 4, 2 and 1 (each within the scatter of the next, the first and the last beyond it).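

In this assay the open chain gives a 1.1-fold lower number from compound 2 to compound 4 (0.05 log units; within the scatter) and so places compound 2 and compound 4 within the scatter of each other; losing cyclopropyl from the amide-type nitrogen is therefore not enough on its own for a step beyond the scatter, and neither is a hexyl chain with its 6 heavy atoms in place of the 3 of cyclopropyl. Set against a 63-fold lower number from compound 1 to compound 3 (1.80 log units; beyond the scatter) where tert-butyl enters, the result shows that this nitrogen does not answer to every replacement of cyclopropyl alike, which the earlier compounds could not show with only one entering group, although the two steps start from compounds that differ in the chloro on the aromatic carbon. Nothing available here bears on why tert-butyl and hexyl part in this way.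

As far as these compounds go, it remains open whether tert-butyl gives a step of similar size on compound 2, where the chloro is present. Also open, from the compounds shown here alone, is where a branched isopropyl group, a shorter butyl chain, or a hexyl chain ending in an amine or a carboxylic acid would fall at this nitrogen.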